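The compounds below may be only part of what the source reports. "The series", "measured", "known", "first", "only" and "open" are said of these compounds alone.

Compound 1 `O=C(NO)[C@H]1CCCCN1S(=O)(=O)N1CC=C(c2ccccc2)CC1` gives 240 nM in a functional assay on MONO-MAC-6 cells (Homo sapiens) for inhibition; on this read-out higher numbers stand for weaker inhibition and lower numbers for stronger inhibition. Compound 2 `COc1ccc(C2=CCN(S(=O)(=O)N3CCCC[C@@H]3C(=O)NO)CC2)cc1` gives 15000 nM.

Compound 2 stands highest of the two numbers; its nearest neighbour, compound 1, lies a 63-fold higher number from compound 1 to compound 2 (1.80 log units; beyond the scatter) away. Compound 3 `COc1cccc(C2=CCN(S(=O)(=O)N3CCCC[C@@H]3C(=O)NO)CC2)c1` differs from compound 2 by 3-methoxyphenyl in place of 4-methoxyphenyl on a double-bonded ring carbon. For the measured compounds named here, the only measured step, a 63-fold higher number from compound 1 to compound 2 (1.80 log units; beyond the scatter), concerns adding the methoxy, not moving it, so no measured step bears directly on the shift from compound 2 to compound 3. A moderate change, most likely toward a lower number, is expected, with wide uncertainty: a 3.0-fold lower number from compound 2 to compound 3 (0.48 log units; beyond the scatter). Compound 3 is estimated at 5000 nM, between 1000 nM and 25000 nM.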

Compound 3, half-maximal inhibitory concentration: 260 nM
Beside the measured number, compound 3's estimate is 19-fold (1.28 log units) above it; the measured number lies below the stated range.
By their numbers in this assay, from the lowest: compounds 1 and 3 (each within the scatter of the next); then compound 2.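

Moving the methoxy alone gave a 58-fold lower number from compound 2 to compound 3 (1.76 log units; beyond the scatter) and so shows that, in this series, where the group sits on the aromatic ring matters, not only whether it is present. Compared with the phenyl of compound 1, the 3-methoxyphenyl of compound 3 gave a 1.1-fold higher number from compound 1 to compound 3 (0.03 log units; within the scatter) and so shows that a methoxy need not raise the number, as the 4-methoxyphenyl of compound 2 did. No evidence on hand explains this difference.

On these data alone, whether an ethoxy, an amine or a carboxylic acid would follow compound 3 or compound 2 remains open.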